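This account rests on a few compounds, and the source may have more. Where it says the series, first, only, none or still open, it means among the compounds named here.

Measured so far:
- Compound 1 `COc1ccc(Cl)cc1S(=O)(=O)NC(=O)NC/C=C1\CCCc2cnn(Cc3ccc(Cl)cc3Cl)c21` gives 8 nM in a functional assay on CHO-K1 cells for antagonist activity at prostaglandin E2 receptor EP3 subtype (Homo sapiens), read by TR-FRET and cAMP accumulation, with a stated time of 30 min; a lower number here means a stronger inhibitor, a higher number a weaker inhibitor.
- Compound 2 `COc1ccc(S(=O)(=O)NC(=O)NC/C=C2\CCCc3cnn(Cc4ccc(Cl)cc4Cl)c32)cc1` gives 29 nM in this assay.

Within the data shown here, compound 2 has the higher of the two numbers, so among the measured compounds it is the weaker inhibitor; the only known step, a 3.6-fold higher number from compound 1 to compound 2 (0.56 log units; beyond the scatter), separates it from compound 1. Compound 3 `Cn1cc(S(=O)(=O)NC(=O)NC/C=C2\CCCc3cnn(Cc4ccc(Cl)cc4Cl)c32)cn1` has not yet been measured. It differs from compound 2 in one place: 1-methyl-1H-pyrazol-4-yl in place of 4-methoxyphenyl on a sulfonyl sulfur. Among the measured compounds shown here, the one measured step touches the same sulfonyl-bound ring, but exchanges one six-membered carbon ring for another; it shows that changes at this ring shift the number by a modest, readable amount. For the measured compounds named here, no measured step exchanges the six-membered ring for a five-membered ring with two nitrogens, so the direction for compound 3 rests on analogy alone. Given that the ring change in a 3.6-fold higher number from compound 1 to compound 2 (0.56 log units; beyond the scatter) moved the number beyond the scatter, a modest weakening is expected for compound 3, by about a 2.4-fold higher number from compound 2 to compound 3 (0.38 log units; beyond the scatter). Compound 3 is therefore estimated at 70 nM, within a range of 15 nM to 300 nM.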

Compound 3, half-maximal inhibitory concentration: 8 nM
Estimate against measurement, compound 3: 8.8-fold (0.94 log units) above, outside the stated range (below it).
By their numbers in this assay, from the lowest: compounds 1 and 3 (each within the scatter of the next); then compound 2.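

On the sulfonyl sulfur, 1-methyl-1H-pyrazol-4-yl in place of 4-methoxyphenyl gives a 3.6-fold lower number from compound 2 to compound 3 (0.56 log units; beyond the scatter) in this assay, so among these compounds a six-membered aromatic ring of carbon only is not needed here for a low number, and a five-membered aromatic ring with 2 hetero atoms and fewer heavy atoms does the job. Set against 5-chloro-2-methoxyphenyl, the same group gives no change at the digits printed from compound 1 to compound 3 (within the scatter), which means that two quite different groups at this place reach the same level and that the chlorine of compound 1 is not the only route to it. Nothing available here explains why the number follows the group on the sulfur in this way.

The compounds shown leave open how the unmethylated 1H-pyrazol-4-yl, a longer chain such as ethyl on the same ring, or a saturated ring such as piperidine on the sulfonyl sulfur would read in this assay. On these data alone, all three compounds also share one core, so it remains open whether the same exchange would give a similar step on a different core.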